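The compounds below may be only part of what the source reports. "The series", "measured", "known", "first", "only" and "open" are said of these compounds alone.

Measured compounds:
- compound 1 `CC1=C(c2ccc(S(C)(=O)=O)cc2)C(c2ccc(OC[C@H](C)N3CC[C@@H](C)C3)cc2)Oc2ccc(O)cc21`: 27 nM
- compound 2 `CC1=C(c2cccc(O)c2)[C@@H](c2ccc(OC[C@H](C)N3CC[C@@H](C)C3)cc2)Oc2ccc(O)cc21`: 59 nM
- compound 3 `CC1=C(c2ccc(F)cc2)C(c2ccc(OC[C@H](C)N3CC[C@@H](C)C3)cc2)Oc2ccc(O)cc21`: 0.4 nM

In a functional assay on MCF7 cells (Homo sapiens) for antiproliferative activity, read by CellTiter-Glo, with a stated time of 5 days (on this read-out lower numbers stand for stronger inhibition and higher numbers for weaker inhibition), compound 2 has the highest number of the three, lying closest to compound 1 and far from compound 3. Compound 4 `CC1=C(c2cccc(O)c2)C(c2ccc(OC[C@H](C)N3CC[C@H](C)C3)cc2)Oc2ccc(O)cc21` differs from compound 2 only in stereochemistry: the two compounds have the same atoms and bonds; at least one stereo element is drawn with a configuration in one of them and without one in the other: 2 of 3 stereo elements differ; a stereocentre at a saturated ring carbon is drawn R in compound 2 and without a configuration in compound 4; a stereocentre at a saturated ring carbon is drawn R in compound 2 and S in compound 4.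

For the measured compounds named here, the one measured step, a 68-fold lower number from compound 1 to compound 3 (1.83 log units; beyond the scatter), is large, but it is an exchange of methylsulfonyl for fluoro. Going by the values given here, no measured step covers a change of configuration, so it shows only that single changes can be large, and it gives no direction here.

In this assay the expected result is a 1.5-fold lower number from compound 2 to compound 4 (0.17 log units; within the scatter), which means no expected shift beyond the scatter, with wide uncertainty. For compound 4 the estimated value is 40 nM, within an expected range of 5 nM to 250 nM.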

Compound 4, half-maximal inhibitory concentration: 0.2 nM
Beside the measured number, compound 4's estimate is 200-fold (2.30 log units) above it, and the stated range ends above it.
By their numbers in this assay, from the lowest: compounds 4 and 3 (each within the scatter of the next); then compound 1; then compound 2.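

In this assay, a 300-fold lower number from compound 2 to compound 4 (2.47 log units; beyond the scatter) arises with atoms and bonds unchanged, so stereochemistry alone can produce a large step in this series, whereas the earlier step was an exchange of substituents. Two stereocentres at saturated ring carbons differ together, so the step cannot be assigned to either one. The comparison is also not a clean inversion at both centres: the fact that one of compounds 2 and 4 is drawn with a defined configuration and the other without, at the place where they differ

Which stereocentre carries the step remains open, as does the effect of each defined configuration taken singly. Also open, going by these compounds, is whether a dimethylamino group in place of the methyl-bearing saturated ring would keep the low number.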